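A few compounds are considered here, and "the series" means these few. Any claim that something is new, unique, unknown or untested is made for them only; others in the source may bear on it.

Going by the values given here, in a physicochemical assay for lipophilicity, at pH 7.4 (on this read-out higher numbers stand for higher lipophilicity and lower numbers for lower lipophilicity), three compounds built on a shared core have numbers so far. Compound 1 (`Cc1cc(C)c(CN2CCc3c(Cl)cc(C(CO)c4ccon4)c(Cl)c3C2=O)c(=O)[nH]1`) gives 2; 2 (2 entries) in both of its entries, and compound 2 (`Cc1cc(C)c(CN2CCc3c(Cl)cc([C@@H](CO)[C@@H]4CCOC4)c(Cl)c3C2=O)c(=O)[nH]1`) gives 2. Compound 3 (`Cc1cc(C)c(CN2CCc3c(Cl)cc([C@H](C)CO)c(Cl)c3C2=O)c(=O)[nH]1`) gives 2.6, which places it above compound 2. Among the compounds with values here, the one measured step here is a number 0.60 log units higher from compound 2 to compound 3 (beyond the scatter), and it comes with methyl in place of oxolan-3-yl.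

Compound 4 (`Cc1cc(C)c(CN2CCc3c(Cl)cc([C@@H](C)CO)c(Cl)c3C2=O)c(=O)[nH]1`) is still unmeasured, and its difference from compound 3 is the two compounds have the same atoms and bonds and differ only in configuration as drawn: 1 of 1 stereo elements differ; a stereocentre at a saturated chain carbon is drawn S in compound 3 and R in compound 4. Only the spatial arrangement at that one carbon changes, and nothing leaves or enters. Within the data shown here, the measured step swaps one group for another, so it gives no size for this change, and no measured pair here differs in configuration alone. With the same atoms and bonds in both compounds, no change beyond the scatter is expected in this assay. The expected step is no change at the digits printed from compound 3 to compound 4 (within the scatter), resting on the value of compound 3, 2.6. The estimate for compound 4 is 2.6, with an expected range from 2.4 to 2.8.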

Compound 4, distribution coefficient: 2.5
The estimate for compound 4 lay 0.10 log units above the measured number; measured number inside the range.
By their numbers in this assay, from the lowest: compound 2; then compounds 4 and 3 (each within the scatter of the next).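

this assay shows a number 0.10 log units lower from compound 3 to compound 4 (within the scatter), so at this saturated chain carbon the drawn configuration leaves no difference that can be read in this assay. This is the cleanest comparison in the set, because nothing else separates the pair: the fact that compounds 3 and 4 differ only in the configuration as drawn The other new step is a number 0.50 log units higher from compound 2 to compound 4 (beyond the scatter), for a group of 4 heavy atoms in place of a group of 8 heavy atoms, so the earlier step beyond the scatter, a number 0.60 log units higher from compound 2 to compound 3 (beyond the scatter), now appears with either drawn configuration of the methyl compound.

The compounds shown leave open whether configuration at this carbon would also make no readable difference with oxolan-3-yl in place of methyl. They also leave open where an amine or a longer chain in place of methyl would fall in this assay.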